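A few compounds are considered here, and "the series" means these few. Any claim that something is new, unique, unknown or untested is made for them only; others in the source may bear on it.

Within the data shown here, compound 1 `O=C(/C=C/C1=Cc2ccccc2OC1)c1ccc(F)cc1` holds the highest of the three numbers measured so far in a functional assay on the whole organism for inhibition, with Mus musculus as the target, with a stated time of 1 h, at a dose of 30 mg/kg by the intraperitoneal route; on this read-out lower numbers stand for less inhibition and higher numbers for more inhibition at the one dose given (going by the name of the read-out): compound 1 gives 65.6%, compound 2 `O=C(/C=C/C1=Cc2ccccc2OC1)c1ccc(Cl)cc1` gives 56.1% and compound 3 `O=C(/C=C/C1=Cc2ccccc2OC1)c1cccc(Br)c1` gives 51.7%. Among the measured compounds shown here, only the step to compound 3 lies beyond the scatter. Compound 4 `O=C(/C=C/C1=Cc2ccccc2OC1)c1ccc(Br)cc1` differs from compound 1 by bromo in place of fluoro on an aromatic carbon. For the measured compounds named here, the steps that bear on this are a number 9.5 percentage points lower from compound 1 to compound 2 (within the scatter) and a number 13.9 percentage points lower from compound 1 to compound 3 (beyond the scatter), with the further step a number 4.4 percentage points lower from compound 2 to compound 3 (within the scatter). Since the chloro of compound 2 enters on an aromatic carbon just as the bromo does here, the step of a number 12.6 percentage points lower from compound 1 to compound 4 (beyond the scatter) is expected to be a small drop, likely within the scatter. Compound 4 is therefore estimated to give 53%, in a range from 38% to 68%.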

Compound 4, a percentage reported as inhibition, in the whole organism at one dose (the size of the read-out at that dose, not a potency): 66%
Beside the measured number, compound 4's estimate is 13 percentage points below it; low and high end bracket the measured number.
By their numbers in this assay, from the lowest: compounds 3, 2, 1 and 4 (each within the scatter of the next, the first and the last beyond it).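

In this assay, replacing fluoro with bromo on this aromatic carbon gives a number 0.4 percentage points higher from compound 1 to compound 4 (within the scatter), and replacing chloro with bromo gives a number 9.9 percentage points higher from compound 2 to compound 4 (within the scatter), so neither halogen swap can be told apart from the scatter. Where the bromine sits does register, with 4-bromophenyl in place of 3-bromophenyl giving a number 14.3 percentage points higher from compound 3 to compound 4 (beyond the scatter). No evidence is available to explain these numbers. From the compounds shown here alone, whether a methoxy, an amine or a carboxylic acid on this carbon would keep the inhibition remains open. So does whether 3-fluorophenyl or 3-chlorophenyl would behave like 3-bromophenyl.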